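Replacing an amino group on compound 3

The compounds below may be only part of what the source reports. "The series", "measured", "known", "first", "only" and "open" are said of these compounds alone.

compound 1 `Cc1cc(=O)c2c(O)cc(OCc3ccc([N+](=O)[O-])cc3)c([C@H]3CCN(C)C[C@H]3O)c2o1` gives 14%
compound 2 `Cc1cc(=O)c2c(O)c(CN3CCCC3CO)c(O)c([C@H]3CCN(C)C[C@H]3O)c2o1` gives 19%
compound 3 `Cc1cc(=O)c2c(O)c(CN(C)CC(=O)O)c(O)c([C@H]3CCN(C)C[C@H]3O)c2o1` gives 18%

These numbers come from a functional assay on Caco-2 cells (Homo sapiens) for inhibition, read by MTT assay, with a stated time of 48 h, tested at 10 uM (a lower number here means less inhibition of growth, a higher number more inhibition of growth at the concentration tested), and all three lie within the usual scatter of one another, so compound 3 cannot be told apart from the other two. In compound 4 `Cc1cc(=O)c2c(O)c(CN3CC(O)CC3C(=O)O)c(O)c([C@H]3CCN(C)C[C@H]3O)c2o1`, 2-carboxy-4-hydroxypyrrolidin-1-yl replaces (carboxymethyl)(methyl)amino on a saturated chain carbon bound to an aromatic carbon (2-carboxy-4-hydroxypyrrolidin-1-yl in place of (carboxymethyl)(methyl)amino on a saturated chain carbon bound to an aromatic carbon). For the measured compounds named here, the one measured change at this place gave a number 1 percentage points lower from compound 2 to compound 3 (within the scatter) and so offers no sign of a real shift. In this assay no step beyond the scatter is therefore expected, in either direction. The expected change is no change at the digits printed from compound 3 to compound 4 (within the scatter) by this estimate. The expected value for compound 4 is 18% (estimated range 9% to 28%).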

Compound 4, percent growth inhibition at one concentration: 19%
Estimate against measurement, compound 4: 1 percentage points below; the range from low to high includes it.
By their numbers in this assay, from the lowest: compounds 1, 3, 2 and 4 (each within the scatter of the next).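

In this assay, 2-carboxy-4-hydroxypyrrolidin-1-yl in place of the open-chain (carboxymethyl)(methyl)amino gave a number 1 percentage points higher from compound 3 to compound 4 (within the scatter) and so adds a five-membered ring at this place with no shift beyond the scatter. In place of 2-(hydroxymethyl)pyrrolidin-1-yl, the same group gave no change at the digits printed from compound 2 to compound 4 (within the scatter) and so shows that the two ring substituents cannot be told apart here either. No measurement is available to explain this lack of difference. The compounds shown leave open whether a morpholin-4-yl or piperazin-1-yl group on this carbon would give a number beyond the scatter.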